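Fluoro removal from compound 2: expected effect

This account rests on a few compounds, and the source may have more. Where it says the series, first, only, none or still open, it means among the compounds named here.

Two compounds of the series carry a number in a functional assay on 143B cells (Homo sapiens) for inhibition, read by CCK-8 assay, with a stated time of 72 h, tested at 1 uM; a lower number here means less inhibition, a higher number more inhibition at the concentration tested (going by the name of the read-out). Compound 1, `COc1ccccc1N1C(=O)CSC1c1cc(F)cc(C(=O)O)c1`, gives 0% in this assay. Compound 2, `O=C(NCCCCc1ccccc1)c1cccc(C2SCC(=O)N2c2cccc(F)c2)c1`, gives 63% in this assay, the highest of the two numbers; the nearest is compound 1, whose value lies lower by a gap beyond the usual scatter. For the measured compounds named here, no pair of measured compounds differs in one place only, so no single-change step is available to anchor a prediction.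

Compound 3, `O=C(NCCCCc1ccccc1)c1cccc(C2SCC(=O)N2c2ccccc2)c1`, is the next candidate. It departs from compound 2 by the following: hydrogen in place of fluoro on an aromatic carbon. Nothing in the measured pair speaks to the fluoro on that ring: compound 1 and compound 2 differ in several places at once, and the large drop between them cannot be assigned to any one of those differences.

In this assay the step is expected to be small, either none beyond the scatter or a modest decrease: a number 8 percentage points lower from compound 2 to compound 3 (within the scatter). Compound 3 is therefore estimated at 55% in this assay, within a range of 35% to 75%.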

Compound 3, a percentage reported as inhibition, at one concentration (the size of the read-out at that concentration, not a potency): 60%
Beside the measured number, compound 3's estimate is 5 percentage points below it; low and high end bracket the measured number.
By their numbers in this assay, from the lowest: compound 1; then compounds 3 and 2 (each within the scatter of the next).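

The change from 3-fluorophenyl to phenyl gives the series its first single-change reading: in this assay the step is a number 3 percentage points lower from compound 2 to compound 3 (within the scatter) and it shows that the fluoro on this ring is not needed for the inhibition seen at the concentration tested. This place, on an aromatic carbon of the ring, therefore accepts hydrogen or fluoro with no difference that can be told apart from the scatter, which the earlier pair, differing in several places at once, could not show. Nothing measured on any property of this group accompanies the step.

Open, on these data alone, is whether a chloro, a trifluoromethyl or an amine at this place on the ring would keep the number in the range of compound 2 and compound 3 or move it beyond the scatter. Also open, as far as these compounds go, is how much of the inhibition rests on the amide chain, which compound 2 and compound 3 share; a shorter chain, or an amine within it, would put that part of the molecule to the test.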